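The source may report more compounds than this note shows. Statements on the series, on what has been measured and on what is new or still open speak of the compounds shown alone.

Three compounds have a reading in an ADME assay on Huh-7 cells (Homo sapiens) for cytotoxicity, read by MTT assay, with a stated time of 72 h; on this read-out higher numbers stand for lower toxicity in this test and lower numbers for higher toxicity in this test. Compound 1 (`CC(C)(C)c1ccc(NC(=O)/C=C/c2c[nH]c3ccccc23)cc1`) gives 10100 nM. Compound 2 (`CC(C)NC(=O)/C=C/c1c[nH]c2ccccc12`) gives > 100000 nM, which is a limit of the assay and not a number. Compound 3 (`CCOC(=O)/C(C)=C/c1c[nH]c2ccccc12`) gives 25300 nM, the higher of the two true numbers in the set, and its gap to compound 1 lies beyond the scatter.

Compound 4 (`C/C(=C\c1c[nH]c2ccccc12)C(=O)O`) is the carboxy counterpart of compound 3: hydrogen in place of ethyl on an oxygen next to a carbonyl group, or ethoxycarbonyl to carboxy. Within the data shown here, no measured pair differs in one place, so the data offer no direct guide to the size of this step.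

The expected change a 3.0-fold higher number from compound 3 to compound 4 (0.47 log units; beyond the scatter) is a rise in this assay beyond the scatter, toward lower toxicity in this test. This expectation is a judgement on the structural change, starting from compound 3 at 25300 nM, and is weakly supported. The reading for compound 4 could also end at the limit of > 100000 nM in this assay, at which 1 of the 3 values shown sits, and only a limit would then be reported. For compound 4 the estimated value is 75000 nM, with an expected range of 30000 nM to 100000 nM.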

Compound 4, half-maximal cytotoxic concentration: > 100000 nM
Compound 4 ended at the assay's limit; the forecaster's own chance of this, stated with the estimate: 50%; middle value at least 1.3-fold (0.12 log units) away from the limit.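

In this assay, among these compounds, the change from ethoxycarbonyl to carboxy, hydrogen in place of ethyl on an oxygen next to a carbonyl group, gives an at least 3.9-fold higher number from compound 3 to compound 4 (0.59 log units; beyond the scatter), the first step between compounds that differ in one place. This shows that the reading at this place responds to the ethyl group: with ethyl, compound 3 has a true number, while with hydrogen the reading for compound 4 moves toward lower toxicity in this test, as far as the assay can follow. From the compounds shown here alone, the step has only a lower bound, and its true size remains unknown, with the top of the scale now reached by more of the series: the limit of > 100000 nM in this assay, at which 2 of the 4 values shown sit.

Going by these compounds, it remains open how the reading in this assay tracks the size of the group on this oxygen, for instance whether a methyl ester, a longer chain such as butyl, or a benzyl ester falls on the same trend as ethyl and hydrogen. On these data alone, it is also open whether a primary amide or an amine-bearing chain in place of the carboxylic acid would keep the reading at the limit or bring it back to a true number.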